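Two Measured Compounds and One Ring Swap at the Amine Nitrogen

The source may hold more compounds than are shown below. What is called first, only, known or untested is meant among the compounds shown, and "the series" means these compounds.

Measured so far:
compound 1 `O/N=C(/CCN1CCN(c2ccccn2)CC1)c1ccccc1Cl`: 64%
compound 2 `CCO/N=C(\CCN1CCN(c2ccccc2OC)CC1)c1ccccc1`: 76%

In a functional assay on HEK293 cells with D(4) dopamine receptor (Homo sapiens) as the target, read by FLIPR (on this read-out higher numbers stand for larger maximal responses and lower numbers for smaller maximal responses), compound 1 gives 64%, while compound 2 gives 76%. Compound 2 stands highest of the two numbers, and the gap down to compound 1 lies beyond the usual scatter. Within the data shown here, compound 1 and compound 2, however, differ in several places at once, so no single structural step between them can be read from these two values.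

Compound 3 `CCO/N=C(\CCN1CCN(c2ncccc2C)CC1)c1ccccc1` has not been measured. It differs from compound 2 in one place: 3-methylpyridin-2-yl in place of 2-methoxyphenyl on an amine nitrogen in a ring. The difference keeps the count of hydrogen-bond donors and acceptors unchanged and removes one heavy atom. Among the measured compounds shown here, with no measured pair that isolates this change, the step from compound 2 to compound 3 is expected to be small, at most a modest decrease, and possibly none beyond the scatter, as a number 8 percentage points lower from compound 2 to compound 3 (within the scatter). Compound 3 is accordingly estimated at 68%, within a range from 50% to 85%.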

Compound 3, largest response reached (reported as efficacy), in percent of the reference or control that the assay uses: 49%
Compound 3: the middle estimate sits 19 percentage points above what was measured; the measured number lies below the stated range.
By their numbers in this assay, from the lowest: compound 3; then compound 1; then compound 2.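

Among these compounds, the swap at the amine nitrogen of the six-membered ring with two nitrogens is the first change here that can be read on its own: in this assay, 3-methylpyridin-2-yl in place of 2-methoxyphenyl gives a number 27 percentage points lower from compound 2 to compound 3 (beyond the scatter). The maximal response at this position therefore depends on which aromatic group the nitrogen carries, even though the swap leaves the counts of hydrogen-bond donors and acceptors unchanged and removes only one heavy atom. Nothing available here accounts for this drop.

The compounds shown leave open whether the step follows the ring nitrogen, the methyl group or the loss of the methoxy group. Going by these compounds, it also remains open whether a 2-methylphenyl or a 3-methoxypyridin-2-yl group at this nitrogen would give a response closer to that of compound 2 or of compound 3.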